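This account rests on a few compounds, and the source may have more. Where it says the series, first, only, none or still open, it means among the compounds named here.

Compounds measured in a functional assay on K562 cells (Homo sapiens), read by XTT assay, with a stated time of 48 h; a higher number here means a weaker inhibitor, a lower number a stronger inhibitor:

compound 1, `COC(=O)c1nnn([C@@H]2O[C@H](CO)[C@H]3OC(C)(C)O[C@H]32)c1I` — > 10000 nM, a limit of the assay
compound 2, `CCOC(=O)C#Cc1c(C(=O)OCC)nnn1[C@@H]1O[C@H](CO)[C@@H](OC(C)C)[C@H]1OC(C)C` — 370 nM

Going by the values given here, compound 2 is the only compound for which this assay gives an actual number, and in this assay compound 2 gives 370 nM. Among the compounds with values here, compound 1 sits at the limit of > 10000 nM in this assay, at which 1 of the 2 values shown sits, so it offers no number to compare against, and no step between two measured compounds is available from these data.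

Compound 3, `CCOC(=O)C#Cc1c(C(=O)OCC)nnn1[C@@H]1O[C@H](COC)[C@@H](OC(C)C)[C@H]1OC(C)C`, is not yet measured. It differs from compound 2 in one place: methyl in place of hydrogen on an oxygen on a saturated carbon. Cut one bond further out, the change reads hydroxy to methoxy, or hydroxymethyl to methoxymethyl, on the sugar-like part of the molecule, while the shared core and the two ester groups are untouched.

Within the data shown here, with no measured step to lean on, the expected step from compound 2 to compound 3 is small, at most a modest weakening, and may well fall within the usual scatter of this assay; the estimated step is a 1.5-fold higher number from compound 2 to compound 3 (0.17 log units; within the scatter). Compound 3 is therefore expected to give about 550 nM in this assay, with a range from 150 nM to 2500 nM.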

Compound 3, half-maximal inhibitory concentration: 550 nM
For compound 3 middle estimate and measured number coincide at the digits printed; the measured number falls inside the stated range.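

In this assay the swap of hydroxymethyl for methoxymethyl, methyl in place of hydrogen on an oxygen on a saturated carbon, gives a 1.5-fold higher number from compound 2 to compound 3 (0.17 log units; within the scatter). Going by these compounds alone, this is the first step that can be read, as the earlier compounds offered no pair differing in one place; it shows that this oxygen can carry a methyl while the number stays within the scatter of the hydroxy compound, so in this assay the hydrogen on that oxygen is not required for activity of this order. Nothing measured here speaks to why the two compounds read alike.

What the compounds shown leave open is whether this tolerance extends beyond a single methyl, for instance to a longer chain such as an ethyl or benzyl ether, to an acetate ester on the same oxygen, or to an amine or a carboxylic acid in place of the hydroxymethyl. They also leave open whether the same swap would read alike on another core, or in a cell line other than the one used in this assay.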